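The source may report more compounds than this note shows. Statements on the series, on what has been measured and on what is new or still open speak of the compounds shown alone.

In an assay on isolated protein for inhibition of Phenylethanolamine N-methyltransferase (Bos taurus) (on this read-out higher numbers stand for weaker inhibition and lower numbers for stronger inhibition), compound 2 `CCCCC(O)CN` gives 345000 nM, the lower of the two numbers shown. Compound 1 `C[Si](C)(C)OC(C#N)C1CCCC1` gives 446000 nM in this assay, and the two values lie within the scatter of each other, so neither compound can be called the stronger inhibitor. Compound 3 `CCCCCC(O)CN` differs from compound 2 by methyl in place of hydrogen on a saturated chain carbon, five bonds along the chain from an oxygen on a saturated carbon. Going by the values given here, no step of this kind has been measured here, and the expected step from compound 2 to compound 3 is a 1.2-fold lower number from compound 2 to compound 3 (0.06 log units; within the scatter), not beyond the scatter in either direction. Compound 3 is therefore estimated at 300000 nM, with a range from 100000 nM to 900000 nM.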

Compound 3, half-maximal inhibitory concentration: 314000 nM
Compound 3: middle estimate off by 1.0-fold (0.02 log units), on the low side; the measured number falls inside the stated range.
By their numbers in this assay, from the lowest: compounds 3, 2 and 1 (each within the scatter of the next).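

In this assay, going by these compounds alone, the first step that can be read at this position is a 1.1-fold lower number from compound 2 to compound 3 (0.04 log units; within the scatter) and it stays within the scatter, so on this pair methyl in place of hydrogen on a saturated chain carbon, five bonds along the chain from an oxygen on a saturated carbon, gives no separation of the two values. Nothing available offers an explanation for this result. Open remains whether ethyl or propyl at this position, or a longer chain, would take the number beyond the scatter, and what a carboxylic acid or an amine there would give.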